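The source may hold more compounds than are shown below. What is called first, only, known or untested is meant among the compounds shown, and "the series" means these compounds.

In a functional assay with Rattus norvegicus as the target (a lower number here means that less compound is needed, a higher number that more compound is needed for the effect), compound 1 (`CCCCCCCCC(=O)NCc1cccc(OC)c1`) reports only a limit, > 100000 nM. Compound 2 (`CCCCCCCCC(=O)NCc1cc(O)cc(OC)c1`) also reports only a limit, > 100000 nM. Compound 3 (`CCCCCCCCC(=O)NCc1ccc(O)cc1OC`) reports only a limit too, > 100000 nM. The series therefore rests on one shared bound: the limit of > 100000 nM in this assay, at which 3 of the 3 values shown sit. Compound 4 (`CCCCCCCCC(=O)NCc1ccc([N+](=O)[O-])c(OC)c1`) alters the core of compound 1 by one substitution, nitro in place of hydrogen on an aromatic carbon. Within the data shown here, the only measured step, a step that the two limits leave unreadable from compound 1 to compound 2, involves a hydroxy group and has no readable size, so it offers no size to carry over. No step beyond the scatter is therefore expected in this assay, in either direction. Compound 4 is expected at 100000 nM, with an estimated range of 20000 nM to 300000 nM. The estimated change is a number no higher from compound 1 to compound 4 (the limit leaves the size open).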

Compound 4, half-maximal effective concentration: 7910 nM
Estimate against measurement, compound 4: 13-fold (1.10 log units) above, outside the stated range (below it).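

In this assay, among these compounds, nitro in place of hydrogen on an aromatic carbon, ortho to a methoxy group and para to a large group, gives an at least 12-fold lower number from compound 1 to compound 4 (1.10 log units; beyond the scatter) and is the first readable change. Among the compounds shown here, the earlier step with hydroxy cannot be read, so this is the first sign that a substitution on this ring can move the number at all. Compound 4 alone leaves the bound shared by the others: the limit of > 100000 nM in this assay, at which 3 of the 4 values shown sit.

Going by these compounds, whether an amine or a carboxylic acid on this same carbon would act like nitro stays open. So does whether a longer chain would shift the value of compound 4.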